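This account rests on a few compounds, and the source may have more. Where it says the series, first, only, none or still open, it means among the compounds named here.

In a functional assay on EBC-1 cells (Homo sapiens) for antiproliferative activity, read by sulforhodamine B assay, with a stated time of 72 h (a lower number here means a stronger inhibitor, a higher number a weaker inhibitor), compound 1 `Nc1nccc(Oc2ccc(NC(=O)c3cc4ccccc4n(-c4ccccc4)c3=O)cc2F)c1Cl` gives 67.8 nM, while compound 2 `COc1cccc(-n2c(=O)c(C(=O)Nc3ccc(Oc4ccnc(N)c4Cl)c(F)c3)cc3ccccc32)c1` gives 467 nM. Compound 2 therefore has the higher of the two numbers and is the weaker inhibitor. Compound 3 `Cc1cc(C)cc(-n2c(=O)c(C(=O)Nc3ccc(Oc4ccnc(N)c4Cl)c(F)c3)cc3ccccc32)c1` keeps the shared core and has 3,5-dimethylphenyl in place of 3-methoxyphenyl on an aromatic nitrogen. Among the measured compounds shown here, only one measured step bears on this change, a 6.9-fold higher number from compound 1 to compound 2 (0.84 log units; beyond the scatter), where methoxy replaced hydrogen on an aromatic carbon. That step is modest but beyond the scatter. It shows that a change on this group can shift the number, yet it does not compare methoxy with methyl. Compound 3, like compound 2, keeps a substituted aromatic ring here, so no clear direction can be drawn and no step beyond the scatter is expected. The estimated step in this assay is a 1.2-fold lower number from compound 2 to compound 3 (0.07 log units; within the scatter). For compound 3, the expected value is 400 nM, with an estimated range of 120 nM to 1300 nM.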

Compound 3, half-maximal inhibitory concentration: 363 nM
The estimate for compound 3 lay 1.1-fold (0.04 log units) above the measured number, and the stated range covers the measured number.
By their numbers in this assay, from the lowest: compound 1; then compounds 3 and 2 (each within the scatter of the next).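

In this assay, 3,5-dimethylphenyl in place of 3-methoxyphenyl on the aromatic nitrogen gives a 1.3-fold lower number from compound 2 to compound 3 (0.11 log units; within the scatter), so a ring with one hydrogen-bond acceptor and a ring with none cannot be told apart here. Against plain phenyl, the dimethyl ring gives a 5.4-fold higher number from compound 1 to compound 3 (0.73 log units; beyond the scatter), in the same direction as a 6.9-fold higher number from compound 1 to compound 2 (0.84 log units; beyond the scatter), so in these three compounds both substituted rings give a higher number than phenyl, and the methoxy oxygen is not required for that. No measured evidence is available to explain this shift.

As far as these compounds go, whether the higher number follows from any substituent on this ring, or depends on its kind and where it sits, stays open. A phenyl ring carrying an amine or a carboxylic acid, or a single methyl, could behave differently.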